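This account rests on a few compounds, and the source may have more. Where it says the series, first, only, none or still open, it means among the compounds named here.

Measured so far in a functional assay on MCF7 cells (Homo sapiens) for antiproliferative activity, read by MTT assay; a lower number here means a stronger inhibitor, a higher number a weaker inhibitor:

compound 1 `NS(=O)(=O)c1ccc(C(=O)N/N=C\c2ccccc2)cc1` gives 14900 nM
compound 2 `NS(=O)(=O)c1ccc(C(=O)N/N=C\c2ccc(F)cc2)cc1` gives 9170 nM
compound 3 `NS(=O)(=O)c1ccc(N/N=C(/CS(=O)(=O)c2ccccc2)c2ccccc2)cc1` gives 3970 nM

Compound 3 has the lowest number of the three in this assay, and its gaps to compound 2 and to compound 1 both lie beyond the scatter. Its core differs from the core shared by compound 1 and compound 2.

Next is compound 4 `NS(=O)(=O)c1ccc(N/N=C(/CS(=O)(=O)c2ccccc2)c2ccc(Cl)cc2)cc1`, not yet measured. It differs from compound 3 by chloro in place of hydrogen on an aromatic carbon, taking phenyl to 4-chlorophenyl: chloro in place of hydrogen on an aromatic carbon.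

Within the data shown here, no chloro step has been measured. The nearest evidence is a single fluoro step, a 1.6-fold lower number from compound 1 to compound 2 (0.21 log units; within the scatter), which lies within the scatter and was measured on the other core. It gives weak support for a slightly lower number and none for a large shift. No change beyond the scatter is therefore expected in this assay, though a small move downward is the likelier direction. The estimate corresponds to an expected 1.3-fold lower number from compound 3 to compound 4 (0.12 log units; within the scatter). For compound 4 the estimated value is 3000 nM, with an expected range of 1200 nM to 7500 nM.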

Compound 4, half-maximal inhibitory concentration: 8010 nM
Compound 4: middle estimate off by 2.7-fold (0.43 log units), on the low side; the whole stated range lies below it.
By their numbers in this assay, from the lowest: compounds 3, 4, 2 and 1 (each within the scatter of the next, the first and the last beyond it).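

In this assay, among these compounds, the first chloro step, phenyl to 4-chlorophenyl on the core of compound 3, reads a 2.0-fold higher number from compound 3 to compound 4 (0.30 log units; within the scatter) and so shows that a chloro at this place, para to a large group, brings no change beyond the scatter. Taken with a 1.6-fold lower number from compound 1 to compound 2 (0.21 log units; within the scatter), a fluoro step on the other core, it gives two halogen steps that both stay within the scatter, and together they fix no direction for a halogen step in this series. No measurement at hand bears on the reason for the size of the chloro step.

The compounds shown leave open how this position responds to groups other than a halogen, such as a methoxy, an amine or a carboxylic acid, any of which would test it far more widely than a single chlorine atom does. They also leave open whether a fluoro on the core of compound 3 or a chloro on the core of compound 1 would read as these two steps do, and what a substituent on the other phenyl ring of compound 3, the one on the sulfone, would do.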